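The compounds below may be only part of what the source reports. "The series", "measured", "known", "first", "only" and "open" are said of these compounds alone.

Compound 1 `O=c1cc(-c2ccccc2)oc2cccc(OCCCN3CCC(O)CC3)c12` gave 91 nM in an assay on isolated protein (Cavia porcellus) with Sigma non-opioid intracellular receptor 1 (Homo sapiens) as the target, read by radioligand binding; on this read-out higher numbers stand for weaker inhibition and lower numbers for stronger inhibition.
Compound 2 `O=c1cc(-c2ccccc2)oc2cccc(OCCCCCCCN3CCC(O)CC3)c12` gave 65 nM in this assay.
Compound 3 `COc1cccc(-c2cc(=O)c3cc(OCCCCCCN4CCC(O)CC4)ccc3o2)c1` gave 111 nM in this assay.

Compound 3 sits among its two companions on this assay: its number lies within the usual scatter of repeats of both compound 1 and compound 2, so no real separation can be claimed among the three. The step to compound 4 `COc1ccc(-c2cc(=O)c3cc(OCCCCCCN4CCC(O)CC4)ccc3o2)cc1` keeps every atom and changes only their arrangement: 4-methoxyphenyl in place of 3-methoxyphenyl on an aromatic carbon. For the measured compounds named here, no measured pair in this set shows such a move, so there is no direct guide to its size. On this assay the shift is expected to be small, in no clear direction, and to stay within the scatter of repeated measurement. Compound 4 is therefore estimated at 95 nM, with a plausible range from 35 nM to 260 nM, which means an expected step of a 1.2-fold lower number from compound 3 to compound 4 (0.07 log units; within the scatter).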

Compound 4, half-maximal inhibitory concentration: 332 nM
Compound 4: middle estimate off by 3.5-fold (0.54 log units), on the low side; the measured number lies above the stated range.
By their numbers in this assay, from the lowest: compounds 2, 1 and 3 (each within the scatter of the next); then compound 4.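

In this assay, 4-methoxyphenyl in place of 3-methoxyphenyl on this aromatic carbon is not a silent exchange: it gives a 3.0-fold higher number from compound 3 to compound 4 (0.48 log units; beyond the scatter). For the compounds shown here, the atoms stay the same, so their arrangement alone separates the pair, and this is the only step here that can be read. Nothing at hand accounts for the shift.

As far as these compounds go, whether a fluorophenyl or a pyridyl group at this place would track compound 3 or compound 4 remains open. So does whether the same exchange would matter with a longer chain.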